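The compounds below may be only part of what the source reports. "The series", "measured", "known", "first", "only" and "open" are said of these compounds alone.

Notes on the series. The shared core carries a variable side group on a saturated chain carbon bound to an oxygen on an unsaturated carbon. Compound 2, `CCC1(Cc2ccccc2)OS(=O)(=O)C=C1OCc1ccc(Cl)c(Cl)c1`, is the reference point for the step below. In an ADME assay on HEL cells (Homo sapiens) for cytotoxicity, with a stated time of 3 days (a higher number here means that more compound is tolerated, a lower number that less compound is tolerated), compound 2 gives >= 20000 nM, which is a limit of the assay and not a number. Compound 1, `CCC1(Cc2ccccc2)OS(=O)(=O)C=C1OCCCCc1ccccc1`, carries 3-phenylpropyl at the same place. In this assay compound 1 gives >= 20000 nM, again a limit of the assay. Among the compounds with values here, the one measured step, a step that the two limits leave unreadable from compound 1 to compound 2, cannot be read because both of its ends sit at the limit of >= 20000 nM in this assay, at which 2 of the 2 values shown sit. Within the data shown here, compound 3, `CCC1(Cc2ccccc2)OS(=O)(=O)C=C1OCCc1ccccc1`, is the next member to be measured. benzyl in place of 3,4-dichlorophenyl on a saturated chain carbon bound to an oxygen on an unsaturated carbon No measured step gives a readable size for a change of this kind; the only comparison available, a step that the two limits leave unreadable from compound 1 to compound 2, shows two limits and nothing more. The expected step is therefore a number no higher from compound 2 to compound 3 (the limit leaves the size open), nothing beyond the scatter. For compound 3 the estimate in this assay is 20000 nM, with a range from 10000 nM to 40000 nM, most probably reported once more as a limit only.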

Compound 3, minimum cytotoxic concentration: >= 20000 nM
Compound 3: only a limit was reported; the forecaster's own chance of this, stated with the estimate: 85%; the middle value sits exactly at the limit.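

Compound 3 is also reported only as a limit of the assay, so the steps linking compound 1, compound 2 and compound 3 cannot be read: the limit of >= 20000 nM in this assay, at which 3 of the 3 values shown sit.

The compounds shown leave open whether changing the side group on the shared core alters the tolerated concentration in this assay at all, as no value stands clear of that limit.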